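A few compounds are considered here, and "the series" means these few. Any claim that something is new, unique, unknown or untested is made for them only; others in the source may bear on it.

Measured so far:
compound 1, `Cc1ccc(-c2cn(C/C=C3\OC(=O)C(OCc4ccccc4)=C3OCc3ccccc3)nn2)cc1`: > 100000 nM
compound 2, `O=C1O[C@H]([C@@H](O)Cn2cc(-c3cccc(O)c3)nn2)C(OCc2ccccc2)=C1OCc1ccccc1`: 62700 nM

Both compounds were tested in a functional assay on HepG2 cells (Homo sapiens) for antiproliferative activity, read by MTT assay, with a stated time of 72 h; a lower number here means a stronger inhibitor, a higher number a weaker inhibitor. For compound 1 the result of > 100000 nM is a limit of the assay rather than a number. Among the compounds with values here, compound 2 gives 62700 nM in this assay and is therefore the only compound here with an actual number. Within the data shown here, the one other value shown is a limit, as the limit of > 100000 nM in this assay, at which 1 of the 2 values shown sits, records. Compound 2 is itself a weak inhibitor in this assay.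

Compound 3, `O=C1O[C@H]([C@@H](O)Cn2cc(CCCCl)nn2)C(OCc2ccccc2)=C1OCc1ccccc1`, has not yet been measured. It differs from compound 2 in one place: 3-chloropropyl in place of 3-hydroxyphenyl on an aromatic carbon. Among the measured compounds shown here, no step between two measured compounds is available, so nothing measured tells how this kind of change moves the numbers. The step of a 1.4-fold higher number from compound 2 to compound 3 (0.13 log units; within the scatter) is expected to be modest, in the direction of weaker inhibition, with a real chance that the assay reports only a limit. Compound 3 is expected to give 85000 nM in this assay, within a range from 30000 nM to 250000 nM.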

Compound 3, half-maximal inhibitory concentration: 35000 nM
Estimate against measurement, compound 3: 2.4-fold (0.39 log units) above; measured number inside the range.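

In this assay, putting 3-chloropropyl in place of 3-hydroxyphenyl on the aromatic carbon of the five-membered ring gives a 1.8-fold lower number from compound 2 to compound 3 (0.25 log units; within the scatter), so this pair of compounds cannot be told apart in this test. Within the data shown here, this is the first reading of a change at this position, and it is a large change in kind: a six-membered aromatic ring carrying one hydrogen-bond donor and one hydrogen-bond acceptor leaves, and an open chain with no ring, donor or acceptor enters, yet the result stays within the scatter, so this pair gives no sign that the aromatic ring or its hydroxyl matters for the weak activity seen here. Nothing measured here offers a reason for this outcome.

A single pair cannot show whether any group at this position moves the number beyond the scatter, and an amine, a carboxylic acid or a longer chain would each test that. A plain propyl chain and a phenyl ring with no hydroxyl would separate the part played by the chlorine from that of the hydroxyl.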